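Dropping the Methoxy: What Compound 3 Might Show

The source may report more compounds than this note shows. Statements on the series, on what has been measured and on what is new or still open speak of the compounds shown alone.

Compound 1, `Cc1ccc2nc(C(=O)Nc3c(F)cc(-c4cccc(F)c4)cc3F)c(C)c(O)c2c1`: 26.5%
Compound 2, `COc1ccc2nc(C(=O)Nc3ccc(-c4ccccc4)cc3)c(C)c(O)c2c1`: 46.3%

Both were measured in a functional assay on A-375 cells (Homo sapiens) for antiproliferative activity, read by MTT assay, with a stated time of 24 h, tested at 33.33 ug/mL; on this read-out higher numbers stand for a stronger effect at the one concentration tested and lower numbers for a weaker effect. Compound 2 gives the higher of the two numbers, with compound 1 some way beneath it, a gap beyond the usual scatter. Compound 3, `Cc1c(C(=O)Nc2ccc(-c3ccccc3)cc2)nc2ccccc2c1O`, is not yet measured. It differs from compound 2 in one place: hydrogen in place of methoxy on an aromatic carbon. Going by the values given here, no pair of measured compounds isolates this change, so the size of the step in this assay is uncertain; a modest fall, or none beyond the scatter, is expected. Compound 3 is expected to give about 40%, within 25% to 55%, an expected step of a number 6.3 percentage points lower from compound 2 to compound 3 (within the scatter).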

Compound 3, a percentage reported as inhibition, at one concentration (the size of the read-out at that concentration, not a potency): 34.3%
For compound 3 the middle estimate is 5.7 percentage points above the measured one; low and high end bracket the measured number.
By their numbers in this assay, from the lowest: compounds 1 and 3 (each within the scatter of the next); then compound 2.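

Going by these compounds alone, replacing methoxy with hydrogen on this aromatic carbon is the first change here isolated in one place, and in this assay it brings a number 12 percentage points lower from compound 2 to compound 3 (beyond the scatter) and so shows that this position affects the read-out. Part of the effect remains without the methoxy. Nothing measured here accounts for the step.

As far as these compounds go, whether an amine, a chlorine atom or a longer ether chain at this carbon would match the methoxy stays open. So does whether the same change would bring a similar step with other groups elsewhere on the core.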